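From compound 1 to compound 4: a decyl chain enters

This account rests on a few compounds, and the source may have more. Where it says the series, first, only, none or still open, it means among the compounds named here.

Among the compounds with values here, compound 1 `O=C1O[C@H]([C@@H](O)Cn2cc(-c3ccc(Br)cc3)nn2)C(OCc2ccccc2)=C1OCc1ccccc1` is the only member of this small set with a numerical result: in a functional assay on SW-620 cells (Homo sapiens) for antiproliferative activity, read by MTT assay, with a stated time of 72 h (on this read-out higher numbers stand for weaker inhibition and lower numbers for stronger inhibition), compound 1 gives 3760 nM. The two other measured compounds each sit at a limit of the assay. For compound 2 `CCCCCc1ccc(-c2cn(C/C=C3\OC(=O)C(OCc4ccccc4)=C3OCc3ccccc3)nn2)cc1` the result in this assay is the limit > 100000 nM. For compound 3 `COc1ccc(-c2cn(C/C=C3\OC(=O)C(OCc4ccccc4)=C3OCc3ccccc3)nn2)cc1` the result in this assay is likewise the limit > 100000 nM. Within the data shown here, the one step between them, a step that the two limits leave unreadable from compound 2 to compound 3, therefore cannot be read, as the limit of > 100000 nM in this assay, at which 2 of the 3 values shown sit, shows.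

Compound 4 `CCCCCCCCCCc1cn(C[C@H](O)[C@H]2OC(=O)C(OCc3ccccc3)=C2OCc2ccccc2)nn1` keeps the framework of compound 1 and differs from it in a single place: decyl in place of 4-bromophenyl on an aromatic carbon. Among the measured compounds shown here, no measured step touches this kind of change, since compounds 2 and 3 differ from compound 1 elsewhere and carry limits only. There is thus no measured basis for expecting a step in this assay in either direction, and the expectation defaults to a value close to that of compound 1, with wide uncertainty. Compound 4 is estimated at 5000 nM in this assay, within a range from 1000 nM to 30000 nM, which means an expected step of a 1.3-fold higher number from compound 1 to compound 4 (0.12 log units; within the scatter).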

Compound 4, half-maximal inhibitory concentration: 45200 nM
Beside the measured number, compound 4's estimate is 9.0-fold (0.96 log units) below it, outside the stated range (above it).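

Within the data shown here, the change at this aromatic carbon of the five-membered aromatic ring with 3 nitrogen gives the first readable step in this assay: replacing 4-bromophenyl with decyl produces a 12-fold higher number from compound 1 to compound 4 (1.08 log units; beyond the scatter). This shows that the group at this position matters in this assay, and that the ring-bearing 4-bromophenyl is the better of the two groups compared here. Compound 4 also shows that a ring at this place is not needed for a numerical result, but nothing shown gives a cause for the large step.

Among these compounds, with only two groups compared at this position, the step cannot be divided among the loss of the bromine, the loss of the ring and the arrival of the long chain; a plain phenyl or a shorter chain such as butyl would bear on that split. From the compounds shown here alone, it also remains open how an amine or a carboxylic acid would fare at this position, and the step between the two compounds at the assay limit still cannot be read.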